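The source may hold more compounds than are shown below. What is called first, only, known or untested is meant among the compounds shown, and "the series" means these compounds.

Within the data shown here, compound 3 `COc1ccc(C(=O)c2sc(Nc3ccc(F)cc3)c(C(=O)O)c2C)cc1` is the only member of this small set for which a number exists. In a functional assay, with a stated time of 150 min, tested at 30 ug/mL (on this read-out higher numbers stand for a stronger effect at the one concentration tested and lower numbers for a weaker effect), compound 3 gives 10.5%. Among the measured compounds shown here, compound 1 `COC(=O)c1c(Nc2ccc(Cl)cc2)sc(C(=O)c2ccc(OC)cc2)c1C` was reported in this assay as "not active" (no number reported), and compound 2 `COc1ccc(C(=O)c2sc(Nc3ccc(C)cc3)c(C(=O)O)c2C)cc1` was likewise reported in this assay as "not active" (no number reported), each without a figure, so no measured step between two compounds can be compared. Compound 4 `COc1ccc(C(=O)c2sc(Nc3ccc(Cl)cc3)c(C(=O)O)c2C)cc1` has not yet been tested; it differs from compound 3 by chloro in place of fluoro on an aromatic carbon. For the measured compounds named here, with no measured step to lean on, and given that compound 3 gives only 10.5%, the move from compound 3 to compound 4 is expected to be a number 0.5 percentage points lower from compound 3 to compound 4 (within the scatter) in this assay, not beyond the usual scatter. Compound 4 is therefore estimated to give 10% in this assay, within a range from 0% to 25%.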

Compound 4, a percentage reported as activity, at one concentration (the size of the read-out at that concentration, not a potency): "not active" (no number reported)
No number was reported for compound 4, so the estimate cannot be set against anything.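

In this assay, among these compounds, no step from compound 3 to compound 4 can be read, as compound 4 has no figure. The compounds shown leave open whether chloro in place of fluoro changes the effect at all. No measured property bears on this result.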